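The compounds below may be only part of what the source reports. "The series", "measured", "known", "first", "only" and "open" are said of these compounds alone.

Compound 3 `O=C(Nc1cccc(-c2oc3cc(-c4ccc(F)cc4)ccc3c(=O)c2O)c1)c1ccc(Br)cc1` gives 9740 nM in a functional assay on HeLa cells (Homo sapiens) for antiproliferative activity, read by CCK-8 assay, with a stated time of 72 h; on this read-out higher numbers stand for weaker inhibition and lower numbers for stronger inhibition. Among the three measured compounds it stands second highest, yet both neighbours lie within the scatter: compound 1 `Cc1ccc(C(=O)Nc2cccc(-c3oc4cc(-c5ccc(F)cc5)ccc4c(=O)c3O)c2)cc1` gives 6190 nM and compound 2 `O=C(Nc1cccc(-c2oc3cc(-c4ccc(F)cc4)ccc3c(=O)c2O)c1)c1ccc(C(F)(F)F)cc1` gives 17400 nM in this assay. Among the compounds with values here, only one measured step is beyond the scatter, a 2.8-fold higher number from compound 1 to compound 2 (0.45 log units; beyond the scatter); the others, a 1.6-fold higher number from compound 1 to compound 3 (0.20 log units; within the scatter) and a 1.8-fold lower number from compound 2 to compound 3 (0.25 log units; within the scatter), are not. Compound 4 `COc1ccc(C(=O)Nc2cccc(-c3oc4cc(-c5ccc(F)cc5)ccc4c(=O)c3O)c2)c(F)c1` carries the change (2-fluoro-4-methoxyphenyl in place of 4-bromophenyl on a carbonyl carbon). All measured steps swap single groups on the same aromatic carbon and span a modest range, so they bear on this change only loosely, and no step beyond the scatter is expected in this assay, a 1.1-fold lower number from compound 3 to compound 4 (0.06 log units; within the scatter). Compound 4 is therefore estimated at 8500 nM, between 3000 nM and 24000 nM.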

Compound 4, half-maximal inhibitory concentration: 16100 nM
Beside the measured number, compound 4's estimate is 1.9-fold (0.28 log units) below it; measured number inside the range.
By their numbers in this assay, from the lowest: compounds 1, 3, 4 and 2 (each within the scatter of the next, the first and the last beyond it).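

In this assay, placing 2-fluoro-4-methoxyphenyl on the carbonyl carbon gives a 1.7-fold higher number from compound 3 to compound 4 (0.22 log units; within the scatter) and a 1.1-fold lower number from compound 2 to compound 4 (0.03 log units; within the scatter), so this group does not separate from 4-bromophenyl or 4-(trifluoromethyl)phenyl. Only 4-methylphenyl stands apart from it, with a 2.6-fold higher number from compound 1 to compound 4 (0.42 log units; beyond the scatter), so compound 1 now differs beyond the scatter from two compounds rather than one. Nothing measured here gives a reason for these differences. From the compounds shown here alone, compound 1 gives 6190 nM, and still open is whether an amine or a carboxylic acid on this ring would give a clearly lower number.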